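The compounds below may be only part of what the source reports. "The series", "measured", "known", "first", "only" and "open" are said of these compounds alone.

Measured so far:
compound 1, `NC(=O)c1c(NC(=O)c2ccc(C(F)(F)F)cc2)sc2c1CCN(Cc1ccc(Cl)cc1Cl)C2`: > 50000 nM in a functional assay on HeLa cells (Homo sapiens) for antiproliferative activity, with a stated time of 24 h; a higher number here means a weaker inhibitor, a lower number a stronger inhibitor
compound 2, `NC(=O)c1c(NC(=O)c2ccccc2Cl)sc2c1CCN(C(=S)Nc1cccc3ccccc13)C2`: 30800 nM in this assay

The result for compound 1 is a limit of the assay rather than a number; the evidence reads (the limit of > 50000 nM in this assay, at which 1 of the 2 values shown sits). Going by the values given here, compound 2 is the only compound here that gives an actual number, and that number is a weak one, far from the range where strong inhibitors sit.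

Compound 3, `COc1ccc(NC(=S)N2CCc3c(sc(NC(=O)c4ccccc4Cl)c3C(N)=O)C2)cc1`, is the next compound to be tested. It shares the whole core of compound 2 and differs in one place: 4-methoxyphenyl in place of naphthalen-1-yl on an amide-type nitrogen. Among the compounds with values here, no measured pair in this set carries this kind of change, so its effect cannot be read from the data, and the only anchor is the weak value of compound 2.

The step from compound 2 to compound 3 is therefore expected to be small, a 1.1-fold higher number from compound 2 to compound 3 (0.06 log units; within the scatter), within the usual scatter, with no firm direction. Compound 3 is estimated at 35000 nM in this assay, with a range from 12000 nM to 100000 nM, and a fair chance that the assay again reports only a limit.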

Compound 3, half-maximal inhibitory concentration: 36400 nM
Compound 3: middle estimate off by 1.0-fold (0.02 log units), on the low side, within the range that was stated.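

Going by these compounds alone, the first measured pair in this set reads a 1.2-fold higher number from compound 2 to compound 3 (0.07 log units; within the scatter), with 4-methoxyphenyl in place of naphthalen-1-yl on an amide-type nitrogen whose other neighbour is the thiocarbonyl carbon. The two groups differ in real ways, with two aromatic rings against one and no hydrogen-bond acceptor against one, yet in this assay the values of the two compounds cannot be told apart, and both remain weak. Why these different groups give such similar values is something the data shown here cannot explain.

From the compounds shown here alone, only these two aromatic groups can be compared at this position, so it remains open whether a simple methyl group, a longer alkyl chain, or a group carrying an amine or a carboxylic acid would give a clearly stronger or weaker value. Within the data shown here, the result for compound 1, > 50000 nM, is a limit of the assay, and since that compound differs from compound 2 in more than one place, it offers no second step to set beside this one.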